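From a Butyl Carbonate to an Aminopropyl Carbamate

The source may hold more compounds than are shown below. What is called first, only, known or untested is meant among the compounds shown, and "the series" means these compounds.

Within the data shown here, in an ADME assay on the whole organism (serum) with Homo sapiens as the target (on this read-out lower numbers stand for a shorter-lived compound and higher numbers for a longer-lived compound), compound 2 `CCCCOC(=O)OCC1OC(n2cc(C)c(=O)[nH]c2=O)CC1N=[N+]=[N-]` gives 0.15 h, the only plain number in this set. Compound 1 `Cc1cn(C2CC(N=[N+]=[N-])C(COC(=O)NCCCC(=O)OC(C)(C)C)O2)c(=O)[nH]c1=O` gives > 48 h in this assay, which is a limit of the assay rather than a number. Compound 3 `Cc1cn(C2CC(N=[N+]=[N-])C(COC(=O)NCCCN)O2)c(=O)[nH]c1=O` differs from compound 2 by (3-aminopropyl)amino in place of butoxy on a carbonyl carbon. Among the measured compounds shown here, no step between measured compounds is available for this change. A step upward in this assay, a 270-fold higher number from compound 2 to compound 3 (2.43 log units; beyond the scatter), is expected because the limit of > 48 h in this assay, at which 1 of the 2 values shown sits, is where compound 1 sits. Compound 3 is therefore estimated at 40 h, with a range from 5 h to 150 h.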

Compound 3, half-life: > 48 h
Compound 3: no number, only a limit (the forecaster's own chance of this, stated with the estimate: 50%); at least 1.2-fold (0.07 log units) between middle value and limit.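

At this carbonyl carbon, (3-aminopropyl)amino in place of butoxy gives, in this assay, an at least 320-fold higher number from compound 2 to compound 3 (2.50 log units; beyond the scatter). Compound 3 gives > 48 h, which is a limit of the assay and not a number. The step from compound 1 to compound 3 cannot be read, as both stand at a limit: the limit of > 48 h in this assay, at which 2 of the 3 values shown sit.

From the compounds shown here alone, whether the step belongs to the carbamate link or to the amine of the aminopropyl chain stays open. A butylamino group on the same carbonyl carbon would tell these two apart.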